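Adding a large group to a short-lived compound

A few compounds are considered here, and "the series" means these few. Any claim that something is new, unique, unknown or untested is made for them only; others in the source may bear on it.

- compound 1 `O=S(=O)(c1cccc(C(F)(F)F)c1)N1CCc2ccc(OCc3c(F)cccc3Cl)cc21`: 0.0483 h
- compound 2 `O=S(=O)(c1cccc(C(F)(F)F)c1)N1CCc2ccc(-c3cc(F)cc(OC(F)F)c3)cc21`: 0.19 h
- compound 3 `O=C(O)CCC1CN(S(=O)(=O)c2cccc(C(F)(F)F)c2)c2cc(-c3cc(F)cc(OC(F)F)c3)ccc21`: 0.408 h

In an ADME assay on microsomes from liver (Mus musculus) for metabolic stability, read by LC-MS, using NADPH, with a stated time of 60 min, tested at 1 uM (on this read-out higher numbers stand for a longer-lived compound and lower numbers for a shorter-lived compound), compound 2 sits in the middle of the three numbers at 0.19 h. The measurements show a 3.9-fold higher number from compound 1 to compound 2 (0.59 log units; beyond the scatter), and then a 2.1-fold higher number from compound 2 to compound 3 (0.33 log units; beyond the scatter). Both steps are modest.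

Compound 4 `O=C(CC1Cc2ccc(-c3cc(F)cc(OC(F)F)c3)cc2N1S(=O)(=O)c1cccc(C(F)(F)F)c1)N1CC2(COC2)C1` has not been measured yet. Its change from compound 2 is a group of 10 heavy atoms (7 carbon, 1 nitrogen, 2 oxygen; 2 four-membered non-aromatic rings with 1 hetero atom each) in place of a hydrogen atom, on a saturated ring carbon. The new group sits next to the ring nitrogen.

The closest guide is compound 3 at 0.408 h, which also gained a group on a saturated ring carbon, although that group is 2-carboxyethyl. Among the compounds with values here, the data contain no compound with the new group of compound 4, so this guide is a loose one. The other measured step, a 3.9-fold higher number from compound 1 to compound 2 (0.59 log units; beyond the scatter), changed a different part of the molecule and says little here.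

A small rise in the same direction is therefore expected, and it may stay within the usual scatter. The expected change is a 1.6-fold higher number from compound 2 to compound 4 (0.20 log units; within the scatter). For compound 4, the estimated half-life is 0.3 h, with an expected range from 0.1 h to 0.8 h.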

Compound 4, half-life: 0.0117 h
Estimate against measurement, compound 4: 26-fold (1.41 log units) above; measured number below the stated range.
By their numbers in this assay, from the lowest: compound 4; then compound 1; then compound 2; then compound 3.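

In this assay this position is far from neutral: a group of 10 heavy atoms with 2 four-membered non-aromatic rings, placed on the saturated ring carbon next to the ring nitrogen, brings a 16-fold lower number from compound 2 to compound 4 (1.21 log units; beyond the scatter) and leaves compound 4 with the lowest of the four numbers. Until now both listed steps had gone upward, including a 2.1-fold higher number from compound 2 to compound 3 (0.33 log units; beyond the scatter) when 2-carboxyethyl replaced hydrogen on a saturated ring carbon, so filling a saturated ring carbon of this core does not in itself go with a longer half-life. Nothing at hand says why the number falls so far.

As far as these compounds go, compound 3 and compound 4 differ in more than one place, so it stays open whether the fall belongs to the new group itself or to the carbon next to the ring nitrogen that carries it. A carboxylic acid, a methyl or a simple amine on that same carbon would help separate the two, and a shorter chain ending in the same carbonyl would show whether the two four-membered rings matter at all.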